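Benzyloxy in place of chloro on the benzyl ring

This account rests on a few compounds, and the source may have more. Where it says the series, first, only, none or still open, it means among the compounds named here.

Measured compounds:
compound 1 `COc1cc(N)c(Cl)cc1NC(=O)C1CCN(Cc2ccc(Cl)cc2)CC1` gives 1.2 mg/kg
compound 2 `CCCCN1CCC(C(=O)Nc2cc(Cl)c(N)cc2OC)CC1` gives > 10 mg/kg, a limit of the assay
compound 3 `COc1cc(N)c(Cl)cc1NC(=O)C1CCN(CC2CCCC2)CC1` gives > 10 mg/kg, a limit of the assay

Going by the values given here, in a functional assay on the whole organism for antagonist activity, with Mus musculus as the target (a higher number here means that more compound is needed for the effect, a lower number that less compound is needed), compound 1 stands apart as the only value that is a number. Compound 2 reaches only a limit of the assay. Compound 3 also reaches only a limit, so that the limit of > 10 mg/kg in this assay, at which 2 of the 3 values shown sit, holds the other two values. The steps of an at least 8.3-fold higher number from compound 1 to compound 2 (0.92 log units; beyond the scatter) and an at least 8.3-fold higher number from compound 1 to compound 3 (0.92 log units; beyond the scatter) both exchange the whole 4-chlorophenyl for a saturated group, and the step that the two limits leave unreadable from compound 2 to compound 3 cannot be read. The untested compound 4 `COc1cc(N)c(Cl)cc1NC(=O)C1CCN(Cc2ccc(OCc3ccccc3)cc2)CC1` keeps the aromatic ring and changes only its substituent: benzyloxy in place of chloro on an aromatic carbon. Among the compounds with values here, no measured step varies a substituent on that ring, so the measured steps bear on this change only indirectly, by showing that loss of the ring itself costs much. A step no larger than the scatter, in either direction, is therefore expected. Compound 4 is expected to give 2 mg/kg, between 0.6 mg/kg and 7 mg/kg. The expected step of a 1.7-fold higher number from compound 1 to compound 4 (0.22 log units; within the scatter) is estimated to lie within the usual scatter.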

Compound 4, dose for half-maximal effect: > 4 mg/kg
Compound 4 ended at the assay's limit; the forecaster's own chance of this, stated with the estimate: 20%; at least 2.0-fold (0.30 log units) between middle value and limit.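

Keeping the aromatic ring is not enough to hold the value of compound 1: in this assay, benzyloxy in place of chloro on an aromatic carbon gives an at least 3.3-fold higher number from compound 1 to compound 4 (0.52 log units; beyond the scatter). The earlier compounds shown here replaced the whole 4-chlorophenyl with saturated groups, whereas this step shows that the substituent on that ring matters on its own, with the ring still in place. Compound 4 sits at a limit of the assay and not at a number: the limit of > 4 mg/kg in this assay, at which 1 of the 4 values shown sits.

From the compounds shown here alone, how far compound 4 lies past that limit stays open, so the full size of this step cannot be read. One exchange at this position also cannot show how fluoro, methoxy or an amine on the same aromatic carbon would compare with chloro.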